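The source may hold more compounds than are shown below. What is called first, only, known or untested is meant among the compounds shown, and "the series" means these compounds.

Measured in a functional assay on CEM-DNR-bulk cells (Homo sapiens), read by MTT assay, with a stated time of 72 h; on this read-out higher numbers stand for weaker inhibition and lower numbers for stronger inhibition:
- compound 1 `CSc1ncnc2c1c(-c1ccsc1)cn2[C@@H]1O[C@H](CO)[C@@H](O)[C@H]1O`: > 20000 nM (a limit)
- compound 2 `COc1nc(N)nc2c1c(-c1ccco1)cn2[C@@H]1O[C@H](CO)[C@@H](O)[C@H]1O`: > 20000 nM (a limit)
- compound 3 `COc1nc(N)nc2c1c(-c1ccoc1)cn2[C@@H]1O[C@H](CO)[C@@H](O)[C@H]1O`: > 20000 nM (a limit)

Compound 3 gives only a limit, > 20000 nM, and no number. It has no place of its own in the series, which so far reads: the limit of > 20000 nM in this assay, at which 3 of the 3 values shown sit.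

The next change leads to compound 4 `COc1nc(N)nc2c1c(-c1ccccc1)cn2[C@@H]1O[C@H](CO)[C@@H](O)[C@H]1O`, with phenyl in place of furan-3-yl on an aromatic carbon. The group sits on a five-membered aromatic ring with 1 nitrogen, part of a fused or bridged system of two rings.

Among the compounds with values here, only one measured step bears on this directly: a step that the two limits leave unreadable from compound 2 to compound 3, with furan-3-yl in place of furan-2-yl. It gives no size and no direction. Within the data shown here, compound 1 differs from compound 3 in more than one place, so it offers no clean step, though it also gives only a limit. Among the measured compounds shown here, no measured compound carries phenyl at this position, and none gives a readable number.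

With nothing to set a size, no step beyond the usual scatter is expected in this assay, and no direction can be assigned. The estimated step is an at least 1.1-fold lower number from compound 3 to compound 4 (0.04 log units; that floor lies within the scatter). The estimate for compound 4 is 18000 nM, with an expected range from 7000 nM to 20000 nM.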

Compound 4, half-maximal inhibitory concentration: > 20000 nM
Compound 4 was reported as a limit (the forecaster's own chance of this, stated with the estimate: 80%); middle value at least 1.1-fold (0.04 log units) away from the limit.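

In this assay compound 4 gives > 20000 nM, a limit and not a number, and the steps to it from compound 2 and compound 3 cannot be read. The series stays at a single reading: the limit of > 20000 nM in this assay, at which 4 of the 4 values shown sit.

The compounds shown leave open how furan-2-yl, furan-3-yl and phenyl rank against one another in this assay.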